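A few compounds are considered here, and "the series" means these few. Any claim that something is new, unique, unknown or untested is made for them only; others in the source may bear on it.

Measured in a functional assay on MKN-45 cells (Homo sapiens) for inhibition, read by CCK-8 assay, with a stated time of 24 h; a lower number here means a stronger inhibitor, a higher number a weaker inhibitor:
- compound 1 `Cc1cccc(-n2cc(-c3ccc(/C=C4\C(=O)Nc5ccccc54)cc3)nn2)c1`: 4690 nM
- compound 2 `Cc1cccc(-n2cc(-c3ccc(/C=C4\C(=O)Nc5ccc(F)cc54)cc3)nn2)c1`: 6810 nM

In this assay compound 2 gives 6810 nM, which lies within the scatter of the value for compound 1. Among the measured compounds shown here, the series so far offers a single measured step, a 1.5-fold higher number from compound 1 to compound 2 (0.16 log units; within the scatter), for fluoro in place of hydrogen on an aromatic carbon, and that step is within the scatter. Compound 3 `Cc1ccc(-n2cc(-c3ccc(/C=C4\C(=O)Nc5ccc(F)cc54)cc3)nn2)cc1` keeps the core of compound 2 and changes only the aryl group: 4-methylphenyl in place of 3-methylphenyl on an aromatic nitrogen. This is 4-methylphenyl in place of 3-methylphenyl on an aromatic nitrogen. For the measured compounds named here, no measured step touches that place, so the data give no direction for the change, and no shift beyond the scatter is expected. The expected step is a 1.2-fold lower number from compound 2 to compound 3 (0.07 log units; within the scatter). Compound 3 is therefore estimated at 5800 nM, with an expected range of 2400 nM to 14000 nM.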

Compound 3, half-maximal inhibitory concentration: 34600 nM
Compound 3: middle estimate off by 6.0-fold (0.78 log units), on the low side; the measured number lies above the stated range.
By their numbers in this assay, from the lowest: compounds 1 and 2 (each within the scatter of the next); then compound 3.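

In this assay, the aryl group on the aromatic nitrogen proves to be a sensitive place: 4-methylphenyl in place of 3-methylphenyl gives a 5.1-fold higher number from compound 2 to compound 3 (0.71 log units; beyond the scatter), although the two groups have the same atoms, joined differently. This is the first step in the series beyond the scatter, whereas the fluoro change, a 1.5-fold higher number from compound 1 to compound 2 (0.16 log units; within the scatter), stayed within it, so among these compounds the aryl group matters more than the fluoro. Nothing measured here explains why this change weakens inhibition.

From the compounds shown here alone, the 4-methylphenyl group appears only alongside the fluoro, so it remains open whether the same step would hold in the core of compound 1. Going by these compounds, it also remains open how an unsubstituted phenyl, or a phenyl carrying a methoxy group or an amine, would behave at this place.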